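From 3-nitrophenyl to 4-nitrophenyl: a series at its limit

The source may hold more compounds than are shown below. What is called first, only, known or untested is meant among the compounds shown, and "the series" means these compounds.

Of the compounds shown here, three have been read in an ADME assay on A549 cells (Homo sapiens) for inhibition, read by MTT assay, with a stated time of 48 h; on this read-out lower numbers stand for stronger inhibition of growth and higher numbers for weaker inhibition of growth. Compound 1 (`O=C1CSc2ccccc2N1Cc1cn(-c2ccc([N+](=O)[O-])cc2)nn1`) gives > 30 ug/mL, which is a limit of the assay and not a number. Compound 2 (`O=C1CSc2ccccc2N1Cc1cn(-c2cccc([N+](=O)[O-])c2)nn1`) gives > 30 ug/mL, again a limit. Compound 3 (`O=C1CSc2ccccc2N1Cc1cn(Cc2cccc([N+](=O)[O-])c2)nn1`) gives > 30 ug/mL, also a limit and the only standing it has. The evidence so far is the limit of > 30 ug/mL in this assay, at which 3 of the 3 values shown sit.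

The next compound is compound 4 (`O=C1CSc2ccccc2N1Cc1cn(Cc2ccc([N+](=O)[O-])cc2)nn1`), which shares the core of compound 3 and differs as follows: 4-nitrophenyl in place of 3-nitrophenyl on a saturated chain carbon bound to an aromatic nitrogen. It carries 4-nitrophenyl in place of 3-nitrophenyl on a saturated chain carbon bound to an aromatic nitrogen. The two have the same atoms, joined differently.

Within the data shown here, no measured step exists to size the change. The expectation rests on compound 3, read at > 30 ug/mL. The estimated step that the limit leaves unreadable from compound 3 to compound 4 is expected to stay within the usual scatter, with no direction expected. The expected value for compound 4 is 45 ug/mL, with an estimated range of 20 ug/mL to 100 ug/mL.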

Compound 4, concentration for 50% growth inhibition in the A549 assay: > 30 ug/mL
Compound 4 was reported as a limit (the forecaster's own chance of this, stated with the estimate: 85%); the middle value lies beyond the limit too.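

In the A549 assay compound 3 gives > 30 ug/mL, which is a limit of the assay and not a number. In the A549 assay compound 4 gives > 30 ug/mL, which is also a limit. In the A549 assay this leaves a step that the two limits leave unreadable from compound 3 to compound 4. The compounds shown leave open whether any member of the series gives a readable concentration for growth inhibition, and how the 3-nitrophenyl and 4-nitrophenyl compounds would compare. In a physicochemical assay, read by spectrophotometry (a lower number here means a stronger inhibitor, a higher number a weaker inhibitor), compound 3 gives 34.1 ug/mL and compound 4 gives 27.4 ug/mL. In the physicochemical assay this is a 1.2-fold lower number from compound 3 to compound 4 (0.10 log units; within the scatter).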